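The compounds below may be only part of what the source reports. "The series", "measured", "known", "first", "only" and "open" are said of these compounds alone.

Series notes. The shared core of compound 1 `CNc1nc(N)c2nc(O)n(Cc3ccccc3)c2n1` carries a methylamino group on the six-membered ring; in a functional assay (spleen, spleen) for activation, with Mus musculus as the target (on this read-out higher numbers stand for an effect only at larger amounts of compound and lower numbers for an effect already at smaller amounts), compound 1 gives 1 uM. Compound 2 `CCCCNc1nc(N)c2nc(O)n(Cc3ccccc3)c2n1` replaces that by butylamino, and in this assay compound 2 gives 1 uM; the step of no change at the digits printed from compound 1 to compound 2 (within the scatter) lies within the scatter. Compound 3 `CCOc1nc(N)c2nc(O)n(Cc3ccccc3)c2n1` carries ethoxy at the same aromatic carbon, and in this assay compound 3 gives 0.1 uM, the lowest number of the three: the steps of a 10-fold lower number from compound 1 to compound 3 (1.00 log units; beyond the scatter) and a 10-fold lower number from compound 2 to compound 3 (1.00 log units; beyond the scatter) are both beyond the scatter.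

Compound 4 `Nc1ncnc2c1nc(O)n2Cc1ccccc1` differs from compound 3 by hydrogen in place of ethoxy on an aromatic carbon, at the carbon between two ring nitrogen atoms. Within the data shown here, no measured step removes a group at this carbon altogether; the two measured steps onto compound 3 show only that the group there shifts the number in this assay, and the size of that shift is the one those two steps give. Compound 4 is therefore expected to give a higher number than compound 3, with the step of a 30-fold higher number from compound 3 to compound 4 (1.48 log units; beyond the scatter) estimated as uncertain in size. For compound 4 in this assay the estimate is 3 uM, with a range of 0.5 uM to 30 uM.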

Compound 4, minimum effective concentration: 10 uM
Beside the measured number, compound 4's estimate is 3.3-fold (0.52 log units) below it; measured number inside the range.
By their numbers in this assay, from the lowest: compound 3; then compounds 1 and 2 (each within the scatter of the next); then compound 4.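

Hydrogen at the carbon between two ring nitrogen atoms gives the series its first reference point for this position: in this assay the steps are (a 100-fold higher number from compound 3 to compound 4 (2.00 log units; beyond the scatter)) for loss of ethoxy, (a 10-fold higher number from compound 2 to compound 4 (1.00 log units; beyond the scatter)) for loss of butylamino and (a 10-fold higher number from compound 1 to compound 4 (1.00 log units; beyond the scatter)) for loss of methylamino. Each of the three groups therefore goes with a lower number than hydrogen, so the earlier contrast between ethoxy and the two amino groups sits on top of a shift that all three share. Among the listed compounds, a group at this carbon is better than none whether it is joined through oxygen or through nitrogen, and the step is largest for ethoxy.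

No measurement here explains these differences. Still open, on these data alone, is whether methoxy, butoxy or a chlorine atom at this carbon would stay near compound 3 or fall back toward compound 4.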